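Working notes: cyclopentyl amide to hydroxycyclobutyl amide

The compounds below may be only part of what the source reports. "The series", "measured", "known", "first", "only" and "open" are said of these compounds alone.

Compound 1 `CC(=O)N[C@@H]1CCC[C@H](C(=O)Nc2cc(-c3cnn4c3CC(C)(C)CC4)ccn2)C1` gives 4.3 uL/min in an ADME assay on cells (Hepatocyte, Homo sapiens) for metabolic stability, using equilibrium dialysis; a lower number here means slower removal, a higher number faster removal of the compound. Compound 2 `CC(=O)N[C@@H]1CCC[C@H](C(=O)Nc2cc(-c3cnn4c3CC(C)(C)C4)c(Cl)cn2)C1` gives 3.5 uL/min in this assay, and compound 3 `CC(=O)N[C@@H]1CC[C@H](C(=O)Nc2cc(-c3cnn4c3CC(C)(C)C4)c(Cl)cn2)C1` gives 5.8 uL/min. Within the data shown here, the only single change measured, a 1.7-fold higher number from compound 2 to compound 3 (0.22 log units; within the scatter), stays within the scatter. Compound 3 carries the highest of the three numbers, yet its gaps to compound 1 and compound 2 are both within the scatter, so no ordering can be read.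

Compound 4 `CC1(C)Cc2c(-c3cc(NC(=O)[C@H]4C[C@@H](O)C4)ncc3Cl)cnn2C1` differs from compound 3 by 3-hydroxycyclobutyl in place of 3-acetamidocyclopentyl on a carbonyl carbon. Among the measured compounds shown here, no measured step touches this replacement; the cyclohexyl-to-cyclopentyl step is the nearest analogue and moved little. Compound 4 is therefore expected to stay near compound 3, with a 1.2-fold lower number from compound 3 to compound 4 (0.06 log units; within the scatter) as the estimated step, giving an expected 5 uL/min in a range from 2.5 uL/min to 10 uL/min.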

Compound 4, intrinsic clearance in a liver preparation (reported as CLH), per the amount of preparation that the assay uses in the Hepatocyte assay: 106 uL/min
The estimate for compound 4 lay 21-fold (1.33 log units) below the measured number; measured number outside the range, above it.
By their numbers in the Hepatocyte assay, from the lowest: compounds 2, 1 and 3 (each within the scatter of the next); then compound 4.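

In the Hepatocyte assay this position proves far from indifferent to the group on the carbonyl carbon, with an 18-fold higher number from compound 3 to compound 4 (1.26 log units; beyond the scatter) and a 30-fold higher number from compound 2 to compound 4 (1.48 log units; beyond the scatter), whereas the change between the two acetamido rings stayed within the scatter. In a physicochemical assay for solubility, in phosphate buffer, at pH 7.4 (on this read-out lower numbers stand for lower solubility and higher numbers for higher solubility), compound 3 gives 35000 nM and compound 4 gives 15000 nM. No measurement shown accounts for the rise in clearance.

From the compounds shown here alone, compound 4 changes ring size and ring substituent together, so their separate contributions remain open. Also open, going by these compounds, is how 3-acetamidocyclobutyl or an amine on the cyclobutyl ring would read.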